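The compounds below may be only part of what the source reports. "The series", "measured", "known", "first", "only" and "open" are said of these compounds alone.

In a functional assay on K562 cells (Homo sapiens) for cytotoxicity, read by trypan blue exclusion, with a stated time of 96 h (a higher number here means a weaker inhibitor, a lower number a stronger inhibitor), compound 1 `COc1ccc(NS(=O)(=O)/C=C/c2cc(OC)c(OC)c(OC)c2)cc1N` gives 15000 nM, and compound 2 `COC(=O)CNc1cc(NS(=O)(=O)/C=C/c2c(OC)cc(OC)cc2OC)ccc1OC` gives 350 nM. Compound 2 therefore holds the lower of the two numbers, with a gap well beyond the scatter. Compound 3 `COc1cc(OC)c(/C=C/S(=O)(=O)Nc2ccc(OC)c(NC(C)C(=O)O)c2)c(OC)c1` has not yet been measured. It departs from compound 2 by carrying 1-carboxyethyl in place of (methoxycarbonyl)methyl on a nitrogen on an aromatic ring. For the measured compounds named here, no measured pair shows what this change does on its own, so the expectation starts from compound 2 at 350 nM and remains uncertain. A modest move towards a weaker result in this assay is expected, possibly not beyond the scatter, and the estimated step is a 1.7-fold higher number from compound 2 to compound 3 (0.23 log units; within the scatter). For compound 3, the expected value is 600 nM, with an estimated range of 80 nM to 5000 nM.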

Compound 3, half-maximal inhibitory concentration: 8 nM
Beside the measured number, compound 3's estimate is 75-fold (1.88 log units) above it; measured number outside the range, below it.
By their numbers in this assay, from the lowest: compound 3; then compound 2; then compound 1.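

On the nitrogen on an aromatic ring, putting 1-carboxyethyl in place of (methoxycarbonyl)methyl gives a 44-fold lower number from compound 2 to compound 3 (1.64 log units; beyond the scatter) in this assay, a step beyond the scatter. This shows that the substituent at this place can move the number strongly, even though the two groups hold the same atoms and differ in how those atoms are joined, with a hydrogen-bond donor present only in 1-carboxyethyl. Nothing available accounts for the size of this step.

The single change combines a free carboxylic acid with a methyl branch on the chain, and the compounds shown do not tell these two apart. As far as these compounds go, whether carboxymethyl, 1-(methoxycarbonyl)ethyl, a primary amide or a longer carboxylic acid chain on that nitrogen would give a similar number remains open.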